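Nitro-to-methyl swap on two unrelated amide series

The source may report more compounds than this note shows. Statements on the series, on what has been measured and on what is new or still open speak of the compounds shown alone.

Measured compounds in a functional assay on SMMC-7721 cells (Homo sapiens) for cytotoxicity, read by MTT assay, with a stated time of 72 h; a higher number here means a weaker inhibitor, a lower number a stronger inhibitor:
compound 1, `Cc1cccc(NC(=O)CSC(=S)N[C@H]2CCOC2=O)c1`, a limit of the assay: > 128000 nM
compound 2, `O=C(CSC(=S)N[C@H]1CCOC1=O)Nc1cccc([N+](=O)[O-])c1`, a limit of the assay: > 128000 nM
compound 3, `O=C(CCl)Nc1ccc(C(=O)/C=C/c2ccc([N+](=O)[O-])cc2)cc1`: 9060 nM

For the measured compounds named here, compound 3 is the only one with a read number; the two others sit at the same limit, (the limit of > 128000 nM in this assay, at which 2 of the 3 values shown sit). The difference between the core of compound 3 and the core of compound 2 is not broken down here.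

The change from compound 2 to compound 1 is methyl in place of nitro on an aromatic carbon. Its step, a step that the two limits leave unreadable from compound 2 to compound 1, cannot be read because both ends are limits, so the pair gives no size for this change.

Compound 4, `Cc1ccc(/C=C/C(=O)c2ccc(NC(=O)CCl)cc2)cc1`, is not yet measured. It differs from compound 3 by methyl in place of nitro on an aromatic carbon. This is the same kind of change as that from compound 2 to compound 1, but the place is not the same: in compound 4 the methyl sits para to a large group, whereas in compound 1 it sits meta to a large group.

For compound 4 the step is expected to be a 1.8-fold higher number from compound 3 to compound 4 (0.25 log units; within the scatter) in this assay. This rests only on compound 3 giving 9060 nM, since the earlier pair supplies no readable size. Compound 4 is therefore estimated at 16000 nM, likely between 4000 nM and 64000 nM.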

Compound 4, half-maximal inhibitory concentration: 22900 nM
Compound 4: middle estimate off by 1.4-fold (0.16 log units), on the low side, and the stated range covers the measured number.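

In this assay, methyl in place of nitro on an aromatic carbon, para to a large group, gives a 2.5-fold higher number from compound 3 to compound 4 (0.40 log units; beyond the scatter), a modest loss of potency on this core. The same change on the core of compound 2 offers no size to set beside this step, as compound 2 and compound 1 each stand at a limit of the assay and not at a read number: the limit of > 128000 nM in this assay, at which 2 of the 4 values shown sit. The change therefore has a size on one core only, so the series shows neither that the step carries over from one core to the other nor that it fails to, and the place of the group on the ring also differs between the two pairs.

Still open, from the compounds shown here alone, is whether the step is particular to nitro or would also appear with an amine or a carboxylic acid at that place on the core of compound 3. Going by these compounds, the size of the change on the core of compound 1 also stays open, as that needs read numbers rather than limits.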